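This account rests on a few compounds, and the source may have more. Where it says the series, first, only, none or still open, it means among the compounds named here.

Three compounds share a core and differ only in the aryl group on a saturated ring carbon. Compound 1 `COc1ccc([C@@H]2[C@H](Oc3ccccc3)C(=O)N2c2cc(OC)c(OC)c(OC)c2)cc1[N+](=O)[O-]` gives 69000 nM in a functional assay on MCF7 cells (Homo sapiens) for antiproliferative activity, read by MTT assay, with stated times of 24 h and 72 h; on this read-out higher numbers stand for weaker inhibition and lower numbers for stronger inhibition. Compound 2 `CCOC(=O)/C=C/c1ccc([C@@H]2[C@H](Oc3ccccc3)C(=O)N2c2cc(OC)c(OC)c(OC)c2)cc1` gives 87000 nM in this assay. Compound 3 `COc1cc(N2C(=O)[C@@H](Oc3ccccc3)[C@H]2c2ccc(S(C)(=O)=O)cc2)cc(OC)c1OC` gives 62000 nM in this assay, the lowest of the three numbers, yet both of its neighbours lie within the scatter: a 1.1-fold lower number from compound 1 to compound 3 (0.05 log units; within the scatter), and a 1.4-fold lower number from compound 2 to compound 3 (0.15 log units; within the scatter).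

Compound 4 `COc1cc(N2C(=O)[C@@H](Oc3ccccc3)[C@H]2c2ccc(N)cc2)cc(OC)c1OC` has not been measured. It differs from compound 3 in one place: amino in place of methylsulfonyl on an aromatic carbon. The two measured steps bear on this change, since each of them also swaps the group on that aryl ring, and neither moved the number beyond the scatter. Three rather different groups at this position therefore gave numbers that cannot be told apart, and nothing in these data points to the amino group behaving differently.

Compound 4 is accordingly expected to give about 62000 nM in this assay, within a range of 25000 nM to 150000 nM, which means an expected step of no change at the digits printed from compound 3 to compound 4 (within the scatter) that stays within the scatter.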

Compound 4, half-maximal inhibitory concentration: 160000 nM
The estimate for compound 4 lay 2.6-fold (0.41 log units) below the measured number; measured number outside the range, above it.
By their numbers in this assay, from the lowest: compounds 3, 1, 2 and 4 (each within the scatter of the next, the first and the last beyond it).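

Among these compounds, the aryl ring on the saturated ring carbon is less indifferent to substitution than the earlier compounds suggested. In this assay, among the compounds shown here, amino in place of methylsulfonyl gives a 2.6-fold higher number from compound 3 to compound 4 (0.41 log units; beyond the scatter) and 4-aminophenyl in place of 4-methoxy-3-nitrophenyl gives a 2.3-fold higher number from compound 1 to compound 4 (0.37 log units; beyond the scatter), two modest steps that are the first changes on this ring to leave the scatter, while amino in place of 2-(ethoxycarbonyl)ethenyl, with a 1.8-fold higher number from compound 2 to compound 4 (0.26 log units; within the scatter), goes against any clean separation of the amino group from the other three. Nothing available here accounts for these steps.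

What the compounds shown leave open is whether the step belongs to the free amino group alone, since a dimethylamino or acetamido group, or a hydroxyl, on the same aromatic carbon would show whether such a group follows compound 4 or compound 3. They also leave open whether the same step would appear with the phenoxy group of the shared core replaced, for instance by a methoxy group, as every compound here carries that phenoxy group.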